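Replacing a methylimidazole with an aminopyridazine on the shared core

The source may hold more compounds than are shown below. What is called first, only, known or untested is meant among the compounds shown, and "the series" means these compounds.

Of the compounds shown here, three built on one amide-linked core have been measured in a physicochemical assay for lipophilicity; a higher number here means a more lipophilic compound, a lower number a more polar compound. Compound 1 `Cc1ccc(-c2cnc(C)n2C)cc1NC(=O)c1ccc(OCc2ccccn2)cc1` gives 2.8. Compound 2 `Cc1cc(C)c(-c2cn(C)cn2)cc1NC(=O)c1ccc(OCc2ccccn2)cc1` gives 3, and compound 3 `Cc1cc(F)c(-c2ncc[nH]2)cc1NC(=O)c1ccc(OCc2ccccn2)cc1` gives 3. Compound 2 and compound 3 agree at the digits given, and the gap from compound 2 down to compound 1 lies within the usual scatter, so the three numbers are, for practical purposes, indistinguishable in this assay.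

Compound 4 `Cc1cc(C)c(-c2ccc(N)nn2)cc1NC(=O)c1ccc(OCc2ccccn2)cc1` has not yet been measured. It differs from compound 2 in one place: 6-aminopyridazin-3-yl in place of 1-methyl-1H-imidazol-4-yl on an aromatic carbon. The entering group carries one hydrogen-bond donor and three hydrogen-bond acceptors, where the leaving group carries none and two, and the six-membered ring with two hetero atoms replaces a five-membered one with two hetero atoms. Going by the values given here, no pair among compounds 1, 2 and 3 shares this change, so the data give no direct measure of its effect; the expectation rests on the nature of the exchange alone.

Compound 4 is expected to come out lower in this assay than compound 2, with a step of a number 0.80 log units lower from compound 2 to compound 4 (beyond the scatter) that goes beyond the scatter. The estimate for compound 4 is 2.2, with a range from 1.6 to 2.8.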

Compound 4, distribution coefficient: 2.6
Estimate against measurement, compound 4: 0.40 log units below, within the range that was stated.
By their numbers in this assay, from the lowest: compounds 4, 1, 2 and 3 (each within the scatter of the next, the first and the last beyond it).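

In this assay, going by these compounds alone, the exchange of 1-methyl-1H-imidazol-4-yl for 6-aminopyridazin-3-yl, on the aromatic carbon ortho to a methyl group and para to a methyl group, amounts to a number 0.40 log units lower from compound 2 to compound 4 (beyond the scatter), and this is the only step at this position that can be read here. Compounds 1, 2 and 3 differ from one another in more than one place and so gave no reading of any single exchange, whereas this pair ties one defined change to a modest downward shift that clears the scatter. The material at hand offers no independent finding that would explain the size or direction of this shift.

The step carries two changes at once, a six-membered aromatic ring in place of a five-membered one and an added amine, and the compounds shown do not tell these apart; a pyridazin-3-yl group with no amine would bear on that question, as would a methylamino or a methoxy group in the amine's place. Going by these compounds, it also remains open whether the same exchange would give a step of similar size with a fluorine on the aromatic ring in place of the para methyl group.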